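The source may report more compounds than this note shows. Statements on the series, on what has been measured and on what is new or still open speak of the compounds shown alone.

Compound 3 `CCCN(CCC)C1=CC(=O)c2nc3n(c2C1=O)[C@H]1OC[C@@H](O)[C@H]1OC3` is one of three compounds tested in a functional assay on MCF7 cells (Homo sapiens) for inhibition, read by sulforhodamine B assay; a lower number here means a stronger inhibitor, a higher number a weaker inhibitor. For compound 3 the assay reports only a limit, > 16000 nM, not a number. Compound 1 `O=C1C=C(Nc2ccccc2)C(=O)c2c1nc1n2[C@H]2OC[C@@H](O)[C@H]2OC1` likewise stands at a limit of this assay, > 4000 nM. For the measured compounds named here, compound 2 `CCOc1ccc(NC2=CC(=O)c3nc4n(c3C2=O)[C@H]2OC[C@@H](O)[C@H]2OC4)cc1` is the one compound with a numerical result, giving 1430 nM in this assay.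

Compound 4 `COc1ccccc1NC1=CC(=O)c2nc3n(c2C1=O)[C@H]1OC[C@@H](O)[C@H]1OC3` has not yet been measured. It differs from compound 3 in one place: (2-methoxyphenyl)amino in place of dipropylamino on a double-bonded ring carbon.

Going by the values given here, two measured steps bear on this change. Swapping anilino for dipropylamino gave a step that the two limits leave unreadable from compound 1 to compound 3; the two limits leave that step unreadable. Adding ethoxy to the anilino ring gave an at least 2.7-fold lower number from compound 1 to compound 2 (0.44 log units; beyond the scatter), a modest gain. Compound 4 carries an anilino group again, now with a methoxy on the ring, so it resembles compound 1 and compound 2 rather than compound 3. The expectation is therefore a lower number, an at least 5.3-fold lower number from compound 3 to compound 4 (0.72 log units; beyond the scatter), though with compound 3 at a limit its exact size cannot be set.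

The estimate for compound 4 in this assay is 3000 nM, with a likely range from 1000 nM to 10000 nM.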

Compound 4, half-maximal inhibitory concentration: > 4000 nM
Compound 4: no number, only a limit; the forecaster's own chance of this, stated with the estimate: 30%; middle value at least 1.3-fold (0.12 log units) away from the limit.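

In this assay compound 4 gives only a limit, > 4000 nM, so a methoxy group on the anilino ring does not yield a measured number here, and this limit is shared with another compound: the limit of > 4000 nM in this assay, at which 2 of the 4 values shown sit. For the compounds shown here, the one readable comparison is an at least 2.7-fold higher number from compound 2 to compound 4 (0.44 log units; beyond the scatter), for 2-methoxyphenyl in place of 4-ethoxyphenyl on the amine nitrogen. Going by these compounds alone, the gain seen with compound 2 therefore does not extend to every alkoxy-substituted anilino ring, and compound 2 remains the only compound here with a numerical result.

The steps from compound 3 and from compound 1 to compound 4 join two limits and cannot be read, so neither the return from dipropylamino to an aromatic amine nor the added methoxy has a measurable size. As far as these compounds go, compound 2 and compound 4 differ in both the length of the ether chain and its place on the ring, leaving those two changes unseparated, and it remains open how a chloro group, a carboxylic acid or a longer ether chain on that ring would behave.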